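The source may report more compounds than this note shows. Statements on the series, on what has been measured and on what is new or still open speak of the compounds shown alone.

In an ADME assay on Vero cells (Chlorocebus sabaeus) for cytotoxicity, read by MTT assay, with a stated time of 72 h (a lower number here means a stronger inhibitor, a higher number a weaker inhibitor), compound 1, whose structure is `CN1CCN(c2nc3c(cc2[N+](=O)[O-])c(=O)c(C(=O)O)cn3-c2ccc(F)cc2)CC1c1ccccc1`, gives 124000 nM. Compound 3, with the structure `CN1CCN(c2nc3c(cc2[N+](=O)[O-])c(=O)c(C(=O)O)cn3C(C)(C)C)CC1c1ccccc1`, is the same molecule with tert-butyl in place of 4-fluorophenyl on an aromatic nitrogen, a change counted as tert-butyl in place of 4-fluorophenyl on an aromatic nitrogen. For compound 3 the reading is > 134000 nM, which is a limit of the assay rather than a number. The step is therefore an at least 1.0-fold higher number from compound 1 to compound 3 (0.03 log units; that floor lies within the scatter), and it rests on (the limit of > 134000 nM in this assay, at which 1 of the 3 values shown sits), so its true size cannot be pinned down more closely.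

Compound 2, whose structure is `O=C(O)c1cn(-c2ccc(F)cc2)c2nc(N3CCN(C(=O)C4COc5ccccc5O4)CC3)c([N+](=O)[O-])cc2c1=O`, carries a different core; how its core differs from that of compound 1 is not broken down here. In this assay compound 2 gives > 54300 nM, again a limit of the assay and not a number, as the limit of > 54300 nM in this assay, at which 1 of the 3 values shown sits, shows.

Compound 4, with the structure `CC(C)(C)n1cc(C(=O)O)c(=O)c2cc([N+](=O)[O-])c(N3CCN(C(=O)C4COc5ccccc5O4)CC3)nc21`, has not yet been measured. It stands to compound 2 as compound 3 stands to compound 1: the change tert-butyl in place of 4-fluorophenyl on an aromatic nitrogen is the same change, at a place described in the same words. Because the earlier step of an at least 1.0-fold higher number from compound 1 to compound 3 (0.03 log units; that floor lies within the scatter) showed no movement beyond the usual scatter, the expected step is a step that the limit leaves unreadable from compound 2 to compound 4. Compound 4 is accordingly estimated at 100000 nM, with a plausible range from 40000 nM to 300000 nM. Since compound 2 gave only a limit, the assay may once more report only a limit for compound 4.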

Compound 4, half-maximal inhibitory concentration: 116000 nM
For compound 4 the middle estimate is 1.2-fold (0.06 log units) below the measured one, and the stated range covers the measured number.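

The step from compound 2 to compound 4 cannot be read, because compound 2 gives only a limit of the assay and not a number: the limit of > 54300 nM in this assay, at which 1 of the 4 values shown sits.

The compounds shown leave open how large any effect of tert-butyl in place of 4-fluorophenyl on an aromatic nitrogen is in this assay, whether between compound 2 and compound 4 or between compound 1 and compound 3.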